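The source may report more compounds than this note shows. Statements on the series, on what has been measured and on what is new or still open speak of the compounds shown alone.

Measured in a functional assay on HeLa cells (Homo sapiens) for cytotoxicity, read by CCK-8 assay; a lower number here means a stronger inhibitor, a higher number a weaker inhibitor:
- compound 1 `Oc1cccc(-c2cc(-c3cccs3)cc(-c3ccccc3O)n2)c1`: > 50000 nM (a limit of the assay, not a number)
- compound 2 `Oc1cccc(-c2cc(-c3cccs3)cc(-c3cccc(O)c3)n2)c1`: 1690 nM
- compound 3 `Oc1ccc(-c2cc(-c3cccs3)cc(-c3cccc(O)c3)n2)cc1`: 4140 nM

Compound 1 stands at the limit of > 50000 nM in this assay, at which 1 of the 3 values shown sits. For the measured compounds named here, it is therefore the only compound here without a true number, and its real value is unknown.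

Compound 4 `Oc1cccc(-c2cc(-c3ccsc3)cc(-c3ccccc3O)n2)c1` has the same atoms as compound 1, joined differently. It carries thiophen-3-yl in place of thiophen-2-yl on an aromatic carbon, opposite the ring nitrogen (thiophen-3-yl in place of thiophen-2-yl on an aromatic carbon).

Going by the values given here, no measured step makes this swap, since compounds 1, 2 and 3 all carry thiophen-2-yl. The measured steps change the hydroxyphenyl group instead. Replacing 2-hydroxyphenyl gave large drops in this assay, namely an at least 29-fold lower number from compound 1 to compound 2 (1.47 log units; beyond the scatter) and an at least 12-fold lower number from compound 1 to compound 3 (1.08 log units; beyond the scatter), while moving the hydroxyl from 3-hydroxyphenyl to 4-hydroxyphenyl gave a modest rise, a 2.4-fold higher number from compound 2 to compound 3 (0.39 log units; beyond the scatter). Compound 4 keeps both hydroxyphenyl groups of compound 1, including the 2-hydroxyphenyl group, so neither large drop applies to it.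

No step beyond the scatter is therefore expected, and the assay may well report only a limit again. The expected change is a number no higher from compound 1 to compound 4 (the limit leaves the size open). The estimate for compound 4 is 50000 nM, with an expected range of 15000 nM to 100000 nM.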

Compound 4, half-maximal inhibitory concentration: > 50000 nM
Compound 4 gave a limit, no number; the forecaster's own chance of this, stated with the estimate: 65%; the middle value sits exactly at the limit.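

For the compounds shown here, compound 1 and compound 4 both end at a limit of this assay rather than a true number, so no step between them can be read: the limit of > 50000 nM in this assay, at which 2 of the 4 values shown sit.

The compounds shown leave open whether thiophen-3-yl in place of thiophen-2-yl changes the true value at all, and whether that swap would matter in compound 2 or compound 3.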